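The compounds below may be only part of what the source reports. "The series", "measured", "known", "first", "only" and "open" are said of these compounds alone.

Measured so far in an ADME assay on L02 cells (Homo sapiens) for inhibition, read by CCK-8 assay, with a stated time of 48 h; on this read-out higher numbers stand for weaker inhibition of growth and lower numbers for stronger inhibition of growth:
Compound 1 `Cc1ccccc1Nc1nc(Nc2cccnc2)ncc1Cl` gives 22900 nM.
Compound 2 `Cc1ccccc1Nc1nc(NCc2ccccc2)ncc1Cl` reaches only the limit > 100000 nM.
Compound 3 `COc1cccc(CNc2nc(Nc3ccc(N4CCN(C)CC4)cn3)ncc2Cl)c1` gives 16200 nM.

Compound 3 and compound 1 give numbers that sit within the scatter of each other, so no order between them can be read. Compound 4 `COc1cccc(Nc2nc(Nc3ccc(N4CCN(C)CC4)cn3)ncc2Cl)c1` differs from compound 3 by 3-methoxyphenyl in place of 3-methoxybenzyl on a nitrogen on an aromatic ring. Among the compounds with values here, the only measured step that bears on this change runs the other way, from pyridin-3-yl to benzyl: an at least 4.3-fold higher number from compound 1 to compound 2 (0.64 log units; beyond the scatter), its size resting on (the limit of > 100000 nM in this assay, at which 1 of the 3 values shown sits). Reversing such a change in compound 3 would be expected to give a lower number, of modest size, in this assay. Compound 4 is therefore estimated at 7000 nM, between 2500 nM and 25000 nM, a step of a 2.3-fold lower number from compound 3 to compound 4 (0.36 log units; beyond the scatter) expected from compound 3.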

Compound 4, concentration for 50% growth inhibition: 3470 nM
The estimate for compound 4 lay 2.0-fold (0.30 log units) above the measured number, within the range that was stated.
By their numbers in this assay, from the lowest: compound 4; then compounds 3 and 1 (each within the scatter of the next). At a limit, above all of these: compound 2.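

In this assay, this change on the nitrogen now has a size read from two numbers, a 4.7-fold lower number from compound 3 to compound 4 (0.67 log units; beyond the scatter). Here the methoxy-bearing ring of carbon stays the same on both sides, so only the linkage to the nitrogen differs, whereas the earlier step also exchanged pyridin-3-yl for an unsubstituted ring and had its size resting on a limit: the limit of > 100000 nM in this assay, at which 1 of the 4 values shown sits.

Open, going by these compounds, is whether a longer chain on this nitrogen would raise the number further, and whether an amine or a carboxylic acid in place of the methoxy group would shift it.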